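This account rests on a few compounds, and the source may have more. Where it says the series, first, only, none or still open, it means among the compounds named here.

In an assay on THP-1 cells for displacement of a labelled ligand from C-C chemokine receptor type 1 (Homo sapiens) (a higher number here means a weaker inhibitor, a lower number a stronger inhibitor), compound 1 `CC(C)[C@@H](NC(=O)c1cccc(F)c1)C(=O)N1CCC(c2ccc(Cl)cc2)CC1` gives 24 nM, compound 2 `CC(C)[C@@H](NC(=O)c1ccc(F)cc1)C(=O)N1CCC(c2ccc(Cl)cc2)CC1` gives 118 nM, and compound 3 `CC(C)CC(=O)N[C@@H](C(=O)N1CCC(c2ccc(Cl)cc2)CC1)C(C)C` gives 32 nM. Among these three numbers compound 3 holds the second highest; its nearest neighbour is compound 1, separated by a 1.3-fold higher number from compound 1 to compound 3 (0.12 log units; within the scatter), and its furthest is compound 2, separated by a 3.7-fold lower number from compound 2 to compound 3 (0.57 log units; beyond the scatter). Compound 4 `CC(C)[C@@H](NC(=O)CCCc1ccccc1)C(=O)N1CCC(c2ccc(Cl)cc2)CC1` differs from compound 3 only at the acyl end of the shared core: phenethyl in place of isopropyl on a saturated chain carbon bound to a carbonyl carbon, which, cut one bond further out, reads isobutyl to 3-phenylpropyl. Among the measured compounds shown here, no measured step swaps one saturated chain for a longer chain carrying a ring at this position. For the measured compounds named here, the steps that bear on it show the acyl group tolerating both an aromatic ring and a branched chain, with the ring-to-chain change within the scatter in a 1.3-fold higher number from compound 1 to compound 3 (0.12 log units; within the scatter) and modest in a 3.7-fold lower number from compound 2 to compound 3 (0.57 log units; beyond the scatter). Compound 4 is therefore expected to stay close to compound 3, with a step of a 1.3-fold higher number from compound 3 to compound 4 (0.10 log units; within the scatter) in this assay. The estimate for compound 4 is 40 nM, in a range from 12 nM to 130 nM.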

Compound 4, half-maximal inhibitory concentration: 95 nM
Compound 4: middle estimate off by 2.4-fold (0.38 log units), on the low side; low and high end bracket the measured number.
By their numbers in this assay, from the lowest: compounds 1 and 3 (each within the scatter of the next); then compounds 4 and 2 (each within the scatter of the next).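

In this assay a longer chain carrying a ring does not behave like the branched chain at this acyl position: going from isobutyl to 3-phenylpropyl gives a 3.0-fold higher number from compound 3 to compound 4 (0.47 log units; beyond the scatter) and so moves beyond the scatter. Against the aromatic acyl groups, 3-phenylpropyl in place of 4-fluorophenyl gives a 1.2-fold lower number from compound 2 to compound 4 (0.09 log units; within the scatter) while 3-phenylpropyl in place of 3-fluorophenyl gives a 4.0-fold higher number from compound 1 to compound 4 (0.60 log units; beyond the scatter) and so the new group matches only the weaker of the two fluorophenyl compounds. Nothing available here accounts for this shift.

The compounds shown leave open whether the step follows the added chain length or the ring, a question that a longer chain without a ring or a benzyl group at this place could separate. On these data alone, how an amine or a carboxylic acid on the chain would read in this assay also stays open.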